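Thiazolyl in place of methylpyrazolyl on the core of compound 3

A few compounds are considered here, and "the series" means these few. Any claim that something is new, unique, unknown or untested is made for them only; others in the source may bear on it.

Working notes. Compound 1 `c1cc(-c2ccn[nH]2)c2c(c1)C(c1ncc[nH]1)CC2` gives 52 nM in a functional assay on CHO cells for agonist activity at Alpha-1A adrenergic receptor (Homo sapiens), read by FLIPR and calcium flux; on this read-out lower numbers stand for an effect already at smaller amounts and higher numbers for an effect only at larger amounts of compound. Compound 2 `Cc1oncc1-c1cccc2c1CCC2c1ncc[nH]1` gives 111 nM in this assay, the step being a 2.1-fold higher number from compound 1 to compound 2 (0.33 log units; beyond the scatter). Compound 3 `Cn1cc(-c2cccc3c2CCC3c2ncc[nH]2)cn1` returns only a limit in this assay, > 2900 nM, and so stands as the weakest of the three. The steps into it were an at least 55-fold higher number from compound 1 to compound 3 (1.74 log units; beyond the scatter) and an at least 26-fold higher number from compound 2 to compound 3 (1.41 log units; beyond the scatter), both ending at the limit of > 2900 nM in this assay, at which 1 of the 3 values shown sits.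

Compound 4 `c1cc(-c2nccs2)c2c(c1)C(c1ncc[nH]1)CC2` differs from compound 3 by 1,3-thiazol-2-yl in place of 1-methyl-1H-pyrazol-4-yl on an aromatic carbon. Within the data shown here, no measured step covers this exact swap; what the two large steps show is that the 1-methyl-1H-pyrazol-4-yl group alone separates compound 3 from compounds 1 and 2. Its removal is therefore expected to give a large step downward, an at least 14-fold lower number from compound 3 to compound 4 (1.16 log units; beyond the scatter), in this assay. Compound 4 is estimated near 200 nM, ranging from 50 nM to 1500 nM.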

Compound 4, half-maximal effective concentration: 426 nM
Compound 4: the middle estimate sits 2.1-fold (0.33 log units) below what was measured; measured number inside the range.
By their numbers in this assay, from the lowest: compound 1; then compound 2; then compound 4. At a limit, above all of these: compound 3.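

The loss seen with 1-methyl-1H-pyrazol-4-yl is not shared by every five-membered aromatic ring on this aromatic carbon: in this assay there is an at least 6.8-fold lower number from compound 3 to compound 4 (0.83 log units; beyond the scatter), and this step starts from a limit, not a number: the limit of > 2900 nM in this assay, at which 1 of the 4 values shown sits.

Even so, 1,3-thiazol-2-yl does not match the other two groups, with a 3.8-fold higher number from compound 2 to compound 4 (0.58 log units; beyond the scatter) and an 8.2-fold higher number from compound 1 to compound 4 (0.91 log units; beyond the scatter). Among the three compounds with numbers, the order at this position is graded, with 1H-pyrazol-5-yl lowest.

As far as these compounds go, each swap changes ring atoms and attachment together, and which feature sets the order stays open. Also open, from the compounds shown here alone, is how an amine, a carboxylic acid or a pyridine ring would read at this carbon.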